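Replacing (Naphthalen-2-yl)methyl with (3,4-Dichlorophenyl)carbonyl

The source may hold more compounds than are shown below. What is called first, only, known or untested is meant among the compounds shown, and "the series" means these compounds.

Of the compounds shown here, three sharing one core have been tested in an in vitro functional assay on RBL cells for antagonist activity at C-C chemokine receptor type 8 (Homo sapiens), read by FLIPR and calcium flux; on this read-out lower numbers stand for stronger inhibition and higher numbers for weaker inhibition. Compound 1 `COc1ccc2nccc(C3CN(C4CCN(Cc5cc6ccccc6[nH]5)CC4)C(=O)O3)c2n1` gives 31.6 nM. Compound 2 `O=C1OC(c2ccc3ccccc3n2)CN1C1CCN(Cc2cc3ccccc3[nH]2)CC1` gives only a limit, < 50200 nM. Compound 3 `COc1ccc2nccc(C3CN(C4CCN(Cc5ccc6ccccc6c5)CC4)C(=O)O3)c2c1` gives 1260 nM, the higher of the two numbers, and its gap to the lower number of compound 1 lies beyond the usual scatter. Compound 4 `COc1ccc2nccc(C3CN(C4CCN(C(=O)c5ccc(Cl)c(Cl)c5)CC4)C(=O)O3)c2c1` has not yet been measured; it differs from compound 3 in one place: (3,4-dichlorophenyl)carbonyl in place of (naphthalen-2-yl)methyl on an amine nitrogen in a ring. Within the data shown here, no measured pair shows a change of this kind, so the size of a 2.0-fold higher number from compound 3 to compound 4 (0.30 log units; within the scatter) can only be expected, not known; a further weakening, somewhat beyond the scatter, seems the more likely direction. Compound 4 is accordingly estimated at 2500 nM, within a range from 400 nM to 15000 nM.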

Compound 4, half-maximal inhibitory concentration: 6310 nM
Estimate against measurement, compound 4: 2.5-fold (0.40 log units) below; the range from low to high includes it.
By their numbers in this assay, from the lowest: compound 1; then compound 3; then compound 4.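

Among these compounds, this is the first pair differing in one place, and it shows that the group on this ring nitrogen matters: (3,4-dichlorophenyl)carbonyl in place of (naphthalen-2-yl)methyl gives a 5.0-fold higher number from compound 3 to compound 4 (0.70 log units; beyond the scatter) in this series. The swap changes the link to the nitrogen and the aromatic part together, so the pair cannot assign the step to either. No measurement shown accounts for the step.

Which of the two changes carries the step stays open. A (3,4-dichlorophenyl)methyl group on the same nitrogen would separate them.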